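The source may report more compounds than this note shows. Statements on the series, on what has been measured and on what is new or still open speak of the compounds shown alone.

Measured so far in a functional assay on SF-539 cells (Homo sapiens) for inhibition, read by sulforhodamine B assay, with a stated time of 48 h; a higher number here means a weaker inhibitor of growth, a lower number a stronger inhibitor of growth:
compound 1 `COc1cc(-c2nn(-c3cccc(NC(=O)Nc4cc(C(F)(F)F)cc(C(F)(F)F)c4)c3)cc2-c2ccncc2)ccc1Cl`: 1710 nM
compound 2 `O=C(Nc1cccc(-n2cc(-c3ccncc3)c(-c3ccc(Cl)c(O)c3)n2)c1)Nc1cc(C(F)(F)F)cc(C(F)(F)F)c1`: 1490 nM
compound 3 `COc1cc(-c2nn(-c3cccc(NC(=O)Nc4ccc(Cl)c(C(F)(F)F)c4)c3)cc2-c2ccncc2)ccc1Cl`: 6340 nM

Compound 1 and compound 2 share one core and differ in a single place, (hydrogen in place of methyl on an oxygen on an aromatic ring). That change produced a 1.1-fold lower number from compound 1 to compound 2 (0.06 log units; within the scatter). Compound 3 carries the same 4-chloro-3-methoxyphenyl group as compound 1 but on a different core; the difference between the two cores is not broken down here. In this assay compound 3 stands at the highest number of the three, with compound 1 nearest and compound 2 furthest, both gaps beyond the scatter.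

Compound 4 `O=C(Nc1cccc(-n2cc(-c3ccncc3)c(-c3ccc(Cl)c(O)c3)n2)c1)Nc1ccc(Cl)c(C(F)(F)F)c1` has not yet been measured. It differs from compound 3 by hydrogen in place of methyl on an oxygen on an aromatic ring, the same change as from compound 1 to compound 2, and the place is described in the same words. Among the compounds with values here, the only precedent for this change is the pair compound 1 and compound 2, and there it made no step worth the name, so the expectation for compound 4 is a step of similar size, with the caveat that a single example on one core is a thin basis for a second core.

Compound 4 is therefore estimated to give about 5800 nM in this assay, an expected step of a 1.1-fold lower number from compound 3 to compound 4 (0.04 log units; within the scatter), because the earlier step of a 1.1-fold lower number from compound 1 to compound 2 (0.06 log units; within the scatter) lay within the scatter. The expected range for compound 4 runs from 3000 nM to 12000 nM, wide enough to allow for the usual scatter and for the second core responding differently.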

Compound 4, concentration for total growth inhibition: 2390 nM
For compound 4 the middle estimate is 2.4-fold (0.39 log units) above the measured one; the whole stated range lies above it.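

In this assay, going from methoxy to hydroxy on the 4-chloro-3-methoxyphenyl group gives a 2.7-fold lower number from compound 3 to compound 4 (0.42 log units; beyond the scatter), a modest step beyond the scatter, whereas the earlier step on the core of compound 1 lay within it. Read singly, the two steps seem to disagree, but set side by side they cannot be told apart: the same change on two cores in this assay, a 1.1-fold lower number (0.06 log units; within the scatter) from compound 1 to compound 2 and a 2.7-fold lower number (0.42 log units; beyond the scatter) from compound 3 to compound 4, 2.3-fold (0.36 log units) apart, within the scatter of two such steps. The data therefore show that, on these two cores, the size of the step does not measurably depend on the core, and they give no ground for saying that the change acts differently on one core than on the other; they do not show that the two steps are equal, and two pairs set no rule for any other core in the series.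

Still open, on these data alone, is what other groups in the same place would do, such as an amine or a carboxylic acid in place of the hydroxy, or a longer chain such as ethoxy or propoxy on the oxygen. Also open, as far as these compounds go, is whether a further core would give a step of like size, which would show how far the change can be carried across the series.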